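Chloro to carboxy on the benzyl ether of a pentylamine chain

The compounds below may be only part of what the source reports. "The series", "measured", "known", "first", "only" and "open" are said of these compounds alone.

Measured so far:
compound 1 `Clc1ccc(COc2ccc(OCCOCCNC3CCCC3)cc2)cc1` — 7670 nM
compound 2 `c1ccc(COc2ccc(OCCOCCNC3CCCCC3)cc2)cc1` — 7370 nM

Two compounds of the series have numbers in a functional assay on SK-OV-3 cells (Homo sapiens) for inhibition, read by CCK-8 assay, with a stated time of 70 h; a higher number here means a weaker inhibitor, a lower number a stronger inhibitor. Compound 1 `Clc1ccc(COc2ccc(OCCOCCNC3CCCC3)cc2)cc1` gives 7670 nM, and compound 2 `c1ccc(COc2ccc(OCCOCCNC3CCCCC3)cc2)cc1` gives 7370 nM. The two values sit within the usual scatter of each other, so compound 1 is neither separated from nor ordered against compound 2 on these numbers; nothing more than that can be read from the pair.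

Compound 3 `O=C(O)c1ccc(COc2ccc(OCCOCCNC3CCCC3)cc2)cc1` is not yet measured. It differs from compound 1 in one place, (carboxy in place of chloro on an aromatic carbon). Within the data shown here, no step between measured compounds bears on this change, so no direction is backed by the data. The working expectation is a modest step, weakening if anything, and possibly no step beyond the scatter. Compound 3 is expected near 12000 nM, with a range from 4000 nM to 40000 nM, meaning an estimated step of a 1.6-fold higher number from compound 1 to compound 3 (0.19 log units; within the scatter).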

Compound 3, half-maximal inhibitory concentration: > 100000 nM
Compound 3: a limit, no number; the forecaster's own chance of this, stated with the estimate: 15%; middle value at least 8.3-fold (0.92 log units) away from the limit.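

In this assay, carboxy in place of chloro on this aromatic carbon, para to a large group, gives an at least 13-fold higher number from compound 1 to compound 3 (1.11 log units; beyond the scatter). Among these compounds, this is the only step read at this position, and it shows that the position does not tolerate every replacement; the earlier pair differs in more than one place and could not show this. Compound 3 gives a limit, not a number, so the step has a floor but no measured size: the limit of > 100000 nM in this assay, at which 1 of the 3 values shown sits.

Going by these compounds, it remains open whether a methyl ester or a primary amide in the same place on the core of compound 1 would read nearer to compound 1 or to compound 3. Also open, on these data alone, is whether the step comes from the loss of chloro or from the entry of carboxy, which a plain hydrogen in that place on the same core would help to separate.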